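Replacing the Dichlorophenyl Ring on the Sulfonyl Sulfur

This account rests on a few compounds, and the source may have more. Where it says the series, first, only, none or still open, it means among the compounds named here.

Of the compounds shown here, two have been measured in a functional assay on HeLa cells for agonist activity at 5-hydroxytryptamine receptor 6 (Homo sapiens), read by cAMP accumulation and immunoassay; a higher number here means a larger maximal response, a lower number a smaller maximal response. Compound 1 `O=S(=O)(c1cccc(Cl)c1)c1cn(C2CCCNC2)c2ncccc12` gives 49%. Compound 2 `O=S(=O)(c1cc(Cl)cc(Cl)c1)c1cn(C2CCCNC2)c2ncccc12` gives 62%. Going by the values given here, the single step between them, a number 13 percentage points higher from compound 1 to compound 2 (beyond the scatter), comes from chloro in place of hydrogen on an aromatic carbon. Among the two numbers known, compound 2 stands highest, and its nearest neighbour, compound 1, lies lower by a step beyond the scatter.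

Compound 3 `O=S(=O)(C1=C(Cl)NC2SC=CN12)c1cn(C2CCCNC2)c2ncccc12` is not yet measured. It differs from compound 2 on the sulfonyl sulfur: a group of 9 heavy atoms (5 carbon, 2 nitrogen, 1 sulfur, 1 chlorine; 2 five-membered non-aromatic rings with 2 hetero atoms each) in place of a group of 8 heavy atoms (6 carbon, 2 chlorine; one six-membered aromatic ring of carbon only), on a sulfonyl sulfur The entire 3,5-dichlorophenyl group is thus exchanged for a group with two five-membered non-aromatic rings, a hydrogen-bond donor and three hydrogen-bond acceptors.

Among the compounds with values here, only the step from compound 1 to compound 2 concerns this part of the molecule, and it was modest. Within the data shown here, no measured step covers the exchange of the whole ring, so the direction is uncertain. Since the group that gave the rise in a number 13 percentage points higher from compound 1 to compound 2 (beyond the scatter) is lost, a modest fall is expected, as the step of a number 17 percentage points lower from compound 2 to compound 3 (beyond the scatter). Compound 3 is therefore estimated at 45%, with a range from 20% to 75%.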

Compound 3, largest response reached (Emax), in percent of the reference or control that the assay uses: 47%
Beside the measured number, compound 3's estimate is 2 percentage points below it; the range from low to high includes it.
By their numbers in this assay, from the lowest: compounds 3 and 1 (each within the scatter of the next); then compound 2.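

In this assay the whole 3,5-dichlorophenyl group on the sulfonyl sulfur can be exchanged without the maximal response disappearing, although the step of a number 15 percentage points lower from compound 2 to compound 3 (beyond the scatter) shows that the new group does not hold the level of compound 2. Set against the phenyl group with a single chlorine, the same kind of exchange gives a number 2 percentage points lower from compound 1 to compound 3 (within the scatter), so a group with two five-membered non-aromatic rings, which shares no ring type with the phenyl groups, reads like the group of compound 1 in this assay. Among these three compounds, then, a six-membered aromatic ring of carbon only is not needed on the sulfonyl sulfur for a response of this size, and the second chlorine on the phenyl ring remains the only change here that gives a higher number. No measurement at hand explains why these groups give the responses they do.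

Going by these compounds, whether the chlorine on the new group contributes stays open, a question that the same group with hydrogen in its place would answer. Equally open, on these data alone, is how a plain phenyl, a pyridine ring or a short alkyl chain on the sulfonyl sulfur would compare with these three compounds.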